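Methoxy for chloro on the cyclopropyl aryl ring

A few compounds are considered here, and "the series" means these few. Any claim that something is new, unique, unknown or untested is made for them only; others in the source may bear on it.

Measured compounds:
- compound 1, `CC(C)C[C@@H](N)CN(C(=O)[C@@H]1C[C@H]1c1ccccc1)c1ccc(-c2ccccc2)cc1`: 1.8 nM
- compound 2, `CC[C@H](C)[C@H](N)CN(C(=O)[C@@H]1C[C@H]1c1ccc(Cl)cc1)c1ccc(-c2ccccc2)cc1`: 4300 nM

In a functional assay for agonist activity at G protein-coupled receptor 88 (Homo sapiens), read by HTRF and cAMP accumulation (on this read-out lower numbers stand for an effect already at smaller amounts and higher numbers for an effect only at larger amounts of compound), compound 1 gives 1.8 nM, whereas compound 2 gives 4300 nM, the higher of the two numbers and far beyond the scatter relative to compound 1. The two structures differ in more than one place, so the gap between them cannot be attributed to any single change; it only shows that compound 2 is the weaker of the pair in this assay.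

Compound 3, `CC[C@H](C)[C@H](N)CN(C(=O)[C@@H]1C[C@H]1c1ccc(OC)cc1)c1ccc(-c2ccccc2)cc1`, has not yet been measured in this assay. It differs from compound 2 in one place:
methoxy in place of chloro on an aromatic carbon
Both groups sit on the same aromatic carbon, and nothing measured here separates the effect of that exchange from the other variations in the pair of measured compounds. With only compound 2 as a direct reference, the expected step from compound 2 to compound 3 in this assay is a 1.4-fold lower number from compound 2 to compound 3 (0.16 log units; within the scatter), small and of uncertain direction, likely within the scatter. Compound 3 is therefore estimated at 3000 nM, with a range from 700 nM to 15000 nM.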

Compound 3, half-maximal effective concentration: > 25000 nM
Compound 3: a limit, no number (the forecaster's own chance of this, stated with the estimate: 15%); middle value at least 8.3-fold (0.92 log units) away from the limit.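

Chloro on this aromatic carbon, para to a large group, is not interchangeable with methoxy, although the estimate treated the exchange as close to neutral. In this assay compound 3 gives > 25000 nM, which is a limit of the assay and not a number. The exchange of chloro for methoxy, with one more heavy atom and one hydrogen-bond acceptor entering, comes with an at least 5.8-fold higher number from compound 2 to compound 3 (0.76 log units; beyond the scatter), the first change in the series that can be read at a single place, and its size is only a lower bound: the limit of > 25000 nM in this assay, at which 1 of the 3 values shown sits.

Open, from the compounds shown here alone, is how a fluoro, a methyl or a hydroxyl on this same carbon would read against chloro and methoxy on the side chain shared by compound 2 and compound 3. Also open, going by these compounds, is whether the exchange would carry the same penalty on compound 1, which has an unsubstituted phenyl and a different side chain, so that neither difference can yet be tied to its value of 1.8 nM.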